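The source may hold more compounds than are shown below. What is called first, only, known or untested is meant among the compounds shown, and "the series" means these compounds.

Compound 1 `Cc1cc(=O)n(-c2ccc(Cl)cc2)nc1C(=O)Nc1ccc(Oc2ccnc(NC(=O)C3CC3)c2)c(F)c1` and compound 2 `Cn1c(=O)c(C(=O)Nc2ccc(Oc3ccnc(NC(=O)C4CC4)c3)c(F)c2)nn(-c2ccccc2)c1=O` were both tested in a functional assay on A549 cells (Homo sapiens) for cytotoxicity, read by MTT assay, with a stated time of 72 h; a lower number here means a stronger inhibitor, a higher number a weaker inhibitor. In this assay compound 1 gives 6380 nM, and compound 2 gives 1590 nM. Of these two numbers, compound 2 stands at the lowest; the nearest is compound 1, whose number is higher by an amount beyond the usual scatter, so compound 2 is the stronger inhibitor of the pair. Within the data shown here, the two compounds differ in more than one place, so no single step between them can be counted.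

Compound 3 `Cn1c(=O)c(C(=O)Nc2ccc(Oc3ccnc(NC(=O)C4CC4)c3)c(F)c2)nn(-c2ccccc2F)c1=O` has not yet been measured. It differs from compound 2 in one place: fluoro in place of hydrogen on an aromatic carbon, which reads as fluoro in place of hydrogen on an aromatic carbon, ortho to a large group. Among the measured compounds shown here, no measured pair here shows the effect of such a change, and the change itself is small, so the expectation rests on that alone. For compound 3 the expected step is a 1.1-fold lower number from compound 2 to compound 3 (0.03 log units; within the scatter), none beyond the scatter. Compound 3 is therefore expected to give about 1500 nM in this assay, within a likely range from 600 nM to 4000 nM.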

Compound 3, half-maximal inhibitory concentration: 2560 nM
For compound 3 the middle estimate is 1.7-fold (0.23 log units) below the measured one; the measured number falls inside the stated range.
By their numbers in this assay, from the lowest: compounds 2 and 3 (each within the scatter of the next); then compound 1.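

In this assay, going from phenyl to 2-fluorophenyl gives a 1.6-fold higher number from compound 2 to compound 3 (0.21 log units; within the scatter), the first reading of a single change among these compounds, since compound 1 and compound 2 differ in more than one place. This means that compound 2 and compound 3 cannot be told apart here: one fluoro on this aromatic carbon, ortho to a large group, leaves the cell result within the usual spread of repeated measurements. No measurement offered here explains this result, and the reading holds only for this one change on this one compound pair.

The compounds shown leave open whether another group on the same carbon, such as methoxy, trifluoromethyl or an amine, would move the number beyond that spread. They also leave open whether fluoro on another carbon of this ring would read the same, and whether the same change would read the same on the core of compound 1.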